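A Single Stereocentre Flipped on Compound 1

The source may report more compounds than this note shows. Statements on the series, on what has been measured and on what is new or still open speak of the compounds shown alone.

Compound 1 `Cc1c(Nc2nc(N)c3c(C#N)c(N4CCC[C@H]4C)n(C)c3n2)cnn1[C@H]1CCOC1` gives 51 nM in an assay on HEK293 cells for inhibition of Leucine-rich repeat serine/threonine-protein kinase 2 variant G2019S (Homo sapiens), with a stated time of 48 h (a higher number here means a weaker inhibitor, a lower number a stronger inhibitor), the lowest of the three numbers recorded so far. Compound 3 `C[C@@H]1CCCN1c1c(C#N)c2c(N)nc(Nc3cn(C)nc3Cl)nc2n1C` gives 54 nM, a value that sits within the scatter of compound 1. Compound 2 `Cc1nn(CC(C)(C)O)cc1Nc1nc(N)c2c(C#N)c(N3CCC[C@H]3C)n(C)c2n1` gives 180 nM, which lies beyond the scatter from compound 1. Compound 4 `Cc1c(Nc2nc(N)c3c(C#N)c(N4CCC[C@H]4C)n(C)c3n2)cnn1[C@@H]1CCOC1` has not yet been measured. It differs from compound 1 in one respect: the two compounds have the same atoms and bonds and differ only in configuration as drawn: 1 of 2 stereo elements differ; a stereocentre at a saturated ring carbon is drawn S in compound 1 and R in compound 4. Within the data shown here, no measured pair in this set differs by configuration alone, so the size of such a step cannot be read from the data. A change of configuration at a saturated ring carbon may move the number either way, and the expectation is a modest step of a 1.8-fold higher number from compound 1 to compound 4 (0.25 log units; within the scatter). Compound 4 is therefore expected to give about 90 nM, with a range from 30 nM to 300 nM.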

Compound 4, half-maximal inhibitory concentration: 80 nM
Compound 4: middle estimate off by 1.1-fold (0.05 log units), on the high side; low and high end bracket the measured number.
By their numbers in this assay, from the lowest: compounds 1, 3 and 4 (each within the scatter of the next); then compound 2.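

In this assay, changing the stereocentre at the saturated ring carbon from S to R gives a 1.6-fold higher number from compound 1 to compound 4 (0.20 log units; within the scatter), so the data show no preference between these two configurations at this position. Among these compounds, the earlier compounds offered no such reading, whereas this pair isolates the stereocentre as the only change: the fact that compounds 1 and 4 differ only in the configuration as drawn.

Still open, from the compounds shown here alone, is whether the other stereocentre, drawn alike in compound 1 and compound 4, would tolerate inversion equally. Also open, going by these compounds, is how the number would respond to a carboxylic acid or a primary amine on that saturated ring.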